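The source may report more compounds than this note shows. Statements on the series, on what has been measured and on what is new or still open speak of the compounds shown alone.

Of the compounds shown here, three built on one shared core have been measured in a functional assay on K562 cells (Homo sapiens) for antiproliferative activity, read by MTT assay, with a stated time of 24 h; on this read-out lower numbers stand for stronger inhibition and higher numbers for weaker inhibition. Compound 1 `COc1ccc(C(=O)/C=C/c2ccc(N3CCCC3)cc2)c2c1C=CC(C)(C)O2` gives 6180 nM, compound 3 `COc1ccc(C(=O)/C=C/c2cccc(C(F)(F)F)c2)c2c1C=CC(C)(C)O2` gives 7850 nM, and compound 2 `COc1ccc(C(=O)/C=C/c2cccc([N+](=O)[O-])c2)c2c1C=CC(C)(C)O2` gives 5870 nM, the lowest of the three, though its gaps to compound 1 and to compound 3 both lie within the scatter. Among the compounds with values here, the one single-point step among them, a 1.3-fold higher number from compound 2 to compound 3 (0.13 log units; within the scatter), is likewise within the scatter. Compound 4 `COc1ccc(C(=O)/C=C/c2ccc(Cl)c(Cl)c2)c2c1C=CC(C)(C)O2` differs from compound 2 by 3,4-dichlorophenyl in place of 3-nitrophenyl on a double-bonded chain carbon bound to a double-bonded chain carbon. Within the data shown here, only the step to compound 3 bears on it, an exchange of one group on that same ring, and it showed nothing beyond the scatter. Compound 4 is therefore expected to sit close to compound 2. The step of a 1.0-fold higher number from compound 2 to compound 4 (0.01 log units; within the scatter) is expected to stay within the scatter. The estimate for compound 4 is 6000 nM, ranging from 3000 nM to 12000 nM.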

Compound 4, half-maximal inhibitory concentration: 9030 nM
Compound 4: the middle estimate sits 1.5-fold (0.18 log units) below what was measured, within the range that was stated.
By their numbers in this assay, from the lowest: compounds 2, 1, 3 and 4 (each within the scatter of the next).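

The exchange of 3-nitrophenyl for 3,4-dichlorophenyl on a double-bonded chain carbon bound to a double-bonded chain carbon gives a 1.5-fold higher number from compound 2 to compound 4 (0.19 log units; within the scatter), so this place has now taken a group with two chlorines and no hydrogen-bond acceptors without a step beyond the scatter. No evidence at hand bears on this result. As far as these compounds go, whether a hydroxyl or a carboxylic acid on this ring would bring a step beyond the scatter remains open, as does any change to the shared core.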